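This account rests on a few compounds, and the source may have more. Where it says the series, first, only, none or still open, it means among the compounds named here.

Compound 1 `Cc1nc(-c2nc[nH]n2)ccc1-c1cnc2c(n1)N(CC1CCOCC1)C(=O)CN2`: 100%
Compound 2 `Cc1nc(-c2nc[nH]n2)ccc1-c1cnc2c(n1)N([C@H]1CC[C@H](O)CC1)C(=O)CN2`: 91%
Compound 3 `COCCN1C(=O)CNc2ncc(-c3ccc(-c4nc[nH]n4)nc3C)nc21`: 91%

In an ADME assay on S9 fraction from liver (Rattus norvegicus) for metabolic stability, with a stated time of 60 min (on this read-out lower numbers stand for a less stable compound and higher numbers for a more stable compound), compound 3 gives 91%, the same number as compound 2, and it lies within the scatter of compound 1. All three measured compounds therefore sit close together.

The next compound is compound 4 `Cc1nc(-c2nc[nH]n2)ccc1-c1cnc2c(n1)N(CCC1CCOCC1)C(=O)CN2`, which differs from compound 3 in one place: oxan-4-yl in place of methoxy on a saturated chain carbon, two bonds along the chain from an amide-type nitrogen in a ring. This is oxan-4-yl in place of methoxy on a saturated chain carbon, two bonds along the chain from an amide-type nitrogen in a ring, so 2-methoxyethyl becomes 2-(oxan-4-yl)ethyl.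

The closest measured comparison exchanges oxan-4-yl and methoxymethyl on a saturated chain carbon bound to that nitrogen, and it gives a number 9 percentage points lower from compound 1 to compound 3 (within the scatter). The other two steps change the same substituent: a number 9 percentage points lower from compound 1 to compound 2 (within the scatter) and no change at the digits printed from compound 2 to compound 3 (within the scatter). Among the measured compounds shown here, none leaves the scatter, and no measured compound carries the 2-(oxan-4-yl)ethyl group, so no step beyond the scatter is expected in this assay. The estimated result is a number 1 percentage points higher from compound 3 to compound 4 (within the scatter). For compound 4 the expected value is 92%, with an estimated range of 78% to 100%.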

Compound 4, percent of the compound remaining: 76%
For compound 4 the middle estimate is 16 percentage points above the measured one; measured number below the stated range.
By their numbers in this assay, from the lowest: compound 4; then compounds 2, 3 and 1 (each within the scatter of the next).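

In this assay, among the compounds shown here, the substituent on the amide-type nitrogen in a ring now gives steps beyond the scatter, which no step among the earlier compounds did: a number 15 percentage points lower from compound 3 to compound 4 (beyond the scatter) and a number 15 percentage points lower from compound 2 to compound 4 (beyond the scatter), both modest. The largest step, also modest, is a number 24 percentage points lower from compound 1 to compound 4 (beyond the scatter), and here the oxan-4-yl ring stays while (oxan-4-yl)methyl becomes 2-(oxan-4-yl)ethyl, so at this position the same ring gives clearly different numbers on the two chains, and its presence alone does not settle the read-out. Nothing measured here bears on the reason for these steps.

As far as these compounds go, it remains open whether the lower number belongs to the 2-(oxan-4-yl)ethyl group alone or continues with a longer chain such as 3-(oxan-4-yl)propyl. From the compounds shown here alone, it is also open whether the ring oxygen plays any part in the step, which a 2-cyclohexylethyl group would test, and how an amine or a carboxylic acid at the end of the 2-ethyl chain would read in this assay.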